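The source may hold more compounds than are shown below. What is called first, only, known or untested is meant among the compounds shown, and "the series" means these compounds.

Values measured in a functional assay on RS4-11 cells (Homo sapiens) for inhibition, read by CCK-8 assay, with a stated time of 48 h; a higher number here means a weaker inhibitor, a lower number a stronger inhibitor:
- compound 1 `O=C(NCCNS(=O)(=O)c1ccc(-c2ccccc2OCc2cccc(O)c2)s1)Nc1cc(Cl)cc(Cl)c1`: > 50000 nM (a limit)
- compound 2 `O=C(NCCNS(=O)(=O)c1ccc(-c2ccccc2Oc2ccc([N+](=O)[O-])c([N+](=O)[O-])c2)s1)Nc1cc(Cl)cc(Cl)c1`: 2100 nM
- compound 3 `O=C(NCCNS(=O)(=O)c1ccc(-c2ccccc2OCc2ccccc2)s1)Nc1cc(Cl)cc(Cl)c1`: > 20000 nM (a limit)

Compound 1 stands at > 50000 nM, which is a limit and not a number. Compound 3 also gives only a limit, > 20000 nM. Among the compounds with values here, compound 2 is the only one with a true number, 2100 nM.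

Compound 4 `Cc1cc(C)cc(NC(=O)NCCNS(=O)(=O)c2ccc(-c3ccccc3OCc3cccc(O)c3)s2)c1` keeps the core of compound 1 and changes one group: 3,5-dimethylphenyl in place of 3,5-dichlorophenyl on an amide-type nitrogen. In words, 3,5-dimethylphenyl takes the place of 3,5-dichlorophenyl on an amide-type nitrogen. Within the data shown here, no measured compound varies this group, so the measured steps bear on it only indirectly. All of them change the group on the oxygen instead. The step of an at least 23-fold lower number from compound 1 to compound 2 (1.37 log units; beyond the scatter) is large, the step of an at least 9.5-fold higher number from compound 2 to compound 3 (0.97 log units; beyond the scatter) is at least modest, and the step that the two limits leave unreadable from compound 1 to compound 3 cannot be read.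

Compound 4 retains the 3-hydroxybenzyl group of compound 1, whereas the one measured gain, an at least 23-fold lower number from compound 1 to compound 2 (1.37 log units; beyond the scatter), came with replacing that group. No step beyond the scatter is therefore expected in this assay. The expected step is a number no higher from compound 1 to compound 4 (the limit leaves the size open). For compound 4 the estimated value is 50000 nM, with an expected range of 20000 nM to 100000 nM.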

Compound 4, half-maximal inhibitory concentration: 5800 nM
Estimate against measurement, compound 4: 8.6-fold (0.94 log units) above, and the stated range ends above it.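

In this assay, the change on the amide-type nitrogen gives an at least 8.6-fold lower number from compound 1 to compound 4 (0.93 log units; beyond the scatter). Within the data shown here, this is the first sign that this end of the molecule, and not only the group on the oxygen, can move the read-out, even though 3,5-dichlorophenyl and 3,5-dimethylphenyl have the same heavy-atom and hydrogen-bond counts. Compound 1 gives only a limit, so the true size of this step stays unknown: the limit of > 50000 nM in this assay, at which 1 of the 4 values shown sits.

Whether 3,5-dimethylphenyl gives a similar step with 3,4-dinitrophenyl or benzyl on the oxygen remains open, as no such pair is shown. Also open, as far as these compounds go, is how other groups on this nitrogen would read, such as 3,5-dimethoxyphenyl or a plain phenyl ring, and so whether the step belongs to the methyl groups specifically.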